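A few compounds are considered here, and "the series" means these few. Any claim that something is new, unique, unknown or untested is made for them only; others in the source may bear on it.

Working notes on the series. Compound 1 `CNc1cc(Oc2ccc(NC(=O)Nc3cccc(C(F)(F)F)c3)cc2)ncn1` and compound 2 `O=C(Nc1ccc(Oc2cc(O)ncn2)cc1)Nc1cccc(C(F)(F)F)c1` share one core and differ in a single group; in an assay on isolated protein for inhibition of serine/threonine-protein kinase TNNI3K (Homo sapiens) (on this read-out higher numbers stand for weaker inhibition and lower numbers for stronger inhibition), compound 1 gives 40 nM and compound 2 gives 3200 nM. For the measured compounds named here, compound 2 thus stands at the highest of the two numbers measured so far, the nearest being compound 1, and the step of an 80-fold higher number from compound 1 to compound 2 (1.90 log units; beyond the scatter) separates them. The next compound, compound 3 `C[C@@H](O)CNc1cc(Oc2ccc(NC(=O)Nc3cccc(C(F)(F)F)c3)cc2)ncn1`, is not yet measured. It differs from compound 2 in one place: (2-hydroxypropyl)amino in place of hydroxy on an aromatic carbon. Going by the values given here, the only measured step that bears on this change is an 80-fold higher number from compound 1 to compound 2 (1.90 log units; beyond the scatter), where a nitrogen-linked substituent in place of the hydroxy went with a large decrease. Compound 3 restores a nitrogen-linked substituent, so a large step downward in this assay is expected from compound 2, of about an 80-fold lower number from compound 2 to compound 3 (1.90 log units; beyond the scatter). For compound 3 the expected value is 40 nM, in the range 10 nM to 200 nM.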

Compound 3, half-maximal inhibitory concentration: 63 nM
For compound 3 the middle estimate is 1.6-fold (0.20 log units) below the measured one; the measured number falls inside the stated range.
By their numbers in this assay, from the lowest: compounds 1 and 3 (each within the scatter of the next); then compound 2.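

Replacing hydroxy with (2-hydroxypropyl)amino on this aromatic carbon gives a 51-fold lower number from compound 2 to compound 3 (1.71 log units; beyond the scatter) in this assay and shows that the large shift is not confined to methylamino: a bigger nitrogen-linked group serves as well. Set against methylamino, the added 1-hydroxyethyl on the chain gives a 1.6-fold higher number from compound 1 to compound 3 (0.20 log units; within the scatter) and so makes no difference that can be read in this assay even with a defined stereocentre and a further hydroxy present. Nothing at hand accounts for either step.

The compounds shown leave open whether the linking nitrogen itself matters, since no carbon-linked group such as ethyl or ether such as methoxy stands at this position, and whether the mirror-image form of the (2-hydroxypropyl)amino group reads the same. Going by these compounds, how dimethylamino or a chain ending in a carboxylic acid would read here also stays open.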